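The source may hold more compounds than are shown below. What is called first, only, known or untested is meant among the compounds shown, and "the series" means these compounds.

In a functional assay on HT-29 cells (Homo sapiens) for cytotoxicity, read by MTT assay, with a stated time of 72 h (on this read-out lower numbers stand for stronger inhibition and higher numbers for weaker inhibition), the measured compounds are:
- compound 1 `O=C(CN1CCN(c2nnc(Cc3ccncc3)c3ccccc23)CC1)Nc1cccc(Br)c1` gives 1350 nM
- compound 2 `O=C(CN1CCN(c2nnc(Cc3ccncc3)c3ccccc23)CC1)Nc1ccc(Br)cc1` gives 1990 nM
- compound 3 `O=C(CN1CCN(c2nnc(Cc3ccccc3)c3ccccc23)CC1)Nc1ccc(F)c(C(F)(F)F)c1` gives 4590 nM

Compound 3 (4590 nM) has the highest number of the three, beyond the scatter from both others. Compound 4 `O=C(CN1CCN(c2nnc(Cc3ccccc3)c3ccccc23)CC1)Nc1cc(C(F)(F)F)ccc1Cl` differs from it in one place, on an amide-type nitrogen, where 2-chloro-5-(trifluoromethyl)phenyl stands in place of 4-fluoro-3-(trifluoromethyl)phenyl (2-chloro-5-(trifluoromethyl)phenyl in place of 4-fluoro-3-(trifluoromethyl)phenyl on an amide-type nitrogen). For the measured compounds named here, the only measured step at that place is a 1.5-fold higher number from compound 1 to compound 2 (0.17 log units; within the scatter) with 4-bromophenyl in place of 3-bromophenyl, and it stays within the scatter. Going by the values given here, no measured compound carries the entering group, so this is weak guidance. The expected step in this assay is a 1.1-fold lower number from compound 3 to compound 4 (0.06 log units; within the scatter) and no shift beyond the scatter is expected. For compound 4 the estimated value is 4000 nM (expected range 1600 nM to 10000 nM).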

Compound 4, half-maximal inhibitory concentration: 66800 nM
For compound 4 the middle estimate is 17-fold (1.22 log units) below the measured one; measured number above the stated range.
By their numbers in this assay, from the lowest: compounds 1 and 2 (each within the scatter of the next); then compound 3; then compound 4.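

In this assay, the aryl group on the amide-type nitrogen turns out to be a sensitive place: the change to 2-chloro-5-(trifluoromethyl)phenyl gives (a 15-fold higher number from compound 3 to compound 4 (1.16 log units; beyond the scatter)), whereas moving the bromine gave only (a 1.5-fold higher number from compound 1 to compound 2 (0.17 log units; within the scatter)). The leaving and entering groups have the same heavy-atom, donor and acceptor counts, so those counts do not separate the two compounds. Nothing available explains the large step.

Going by these compounds, it remains open whether the chlorine or the new place of the trifluoromethyl matters more. An amine or methoxy group in place of that chlorine is also untested in the compounds shown.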